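This account rests on a few compounds, and the source may have more. Where it says the series, first, only, none or still open, it means among the compounds named here.

In a functional assay on HL-60 cells (Homo sapiens) for cytotoxicity, read by MTT assay, with a stated time of 72 h (a higher number here means a weaker inhibitor, a lower number a stronger inhibitor), compound 1 `COc1ccc(S(=O)(=O)c2nc3ccccc3nc2N2CCCC2)cc1` gives 16000 nM, compound 2 `COc1ccc(S(=O)(=O)c2nc3ccccc3nc2N2CCCC(O)C2)cc1` gives 3050 nM, and compound 3 `O=S(=O)(c1ccccc1)c1nc2ccccc2nc1N1CCC(O)CC1` gives 2900 nM. Compound 3 thus sits level with compound 2 and well under compound 1. Compound 4 `COc1ccc(S(=O)(=O)c2nc3ccccc3nc2N2CCC(O)CC2)cc1` differs from compound 3 by methoxy in place of hydrogen on an aromatic carbon, para to a large group. For the measured compounds named here, the one measured step, a 5.2-fold lower number from compound 1 to compound 2 (0.72 log units; beyond the scatter), changes a different place, so no measured step isolates this methoxy. Compound 2 carries the methoxy and compound 3 lacks it, yet they differ elsewhere too and their values agree. No step beyond the scatter is therefore expected in this assay. The estimated step is a 1.0-fold higher number from compound 3 to compound 4 (0.01 log units; within the scatter). Compound 4 is expected at 3000 nM, within 1200 nM to 7500 nM.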

Compound 4, half-maximal inhibitory concentration: 3230 nM
Compound 4: middle estimate off by 1.1-fold (0.03 log units), on the low side; low and high end bracket the measured number.
By their numbers in this assay, from the lowest: compounds 3, 2 and 4 (each within the scatter of the next); then compound 1.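

In this assay, methoxy in place of hydrogen, para to a large group, now has its own measured step, a 1.1-fold higher number from compound 3 to compound 4 (0.05 log units; within the scatter), so this assay does not separate phenyl from 4-methoxyphenyl. With the methoxy kept, 4-hydroxypiperidin-1-yl in place of 3-hydroxypiperidin-1-yl also stays within the scatter, a 1.1-fold higher number from compound 2 to compound 4 (0.02 log units; within the scatter). Against pyrrolidin-1-yl, 4-hydroxypiperidin-1-yl gives a 5.0-fold lower number from compound 1 to compound 4 (0.69 log units; beyond the scatter), a step beyond the scatter. No measurement at hand explains these numbers. On these data alone, whether a larger alkoxy chain, an amine or a carboxylic acid at the same place would also leave the number level remains open.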